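The source may hold more compounds than are shown below. What is called first, only, known or untested is meant among the compounds shown, and "the series" means these compounds.

Three compounds share one core. In an in vitro assay on HEK385-7 cells for displacement of a labelled ligand from prostaglandin D2 receptor 2 (Homo sapiens) (a higher number here means a weaker inhibitor, a lower number a stronger inhibitor), compound 1 `O=C(O)Cc1sc(C(c2ccccc2)c2ccc(Cl)cc2)nc1-c1ccc(Cl)cc1` gives 45 nM and compound 2 `O=C(O)Cc1sc(C(c2ccccc2)c2ccc(F)cc2)nc1-c1ccc(Cl)cc1` gives 17 nM. Among the compounds with values here, the only single step measured is a 2.6-fold lower number from compound 1 to compound 2 (0.42 log units; beyond the scatter). Compound 3 `O=C(O)Cc1sc(C(c2ccc(F)cc2)c2ccc(F)cc2)nc1-c1ccccc1` gives 16 nM in this assay, the lowest of the three numbers, within the scatter of compound 2 and beyond it only against compound 1. Compound 4 `O=C(O)Cc1sc(C(c2ccc(F)cc2)c2ccc(F)cc2)nc1-c1ccnc(N2CCC2)c1` differs from compound 3 in one place: 2-(azetidin-1-yl)pyridin-4-yl in place of phenyl on an aromatic carbon. Within the data shown here, no measured step touches this kind of change; the one step seen is a different change, so nothing shows how this assay responds to it. The expectation for compound 4 is therefore a small and uncertain shift, a 1.1-fold lower number from compound 3 to compound 4 (0.03 log units; within the scatter). Compound 4 is estimated at 15 nM, between 4 nM and 60 nM.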

Compound 4, half-maximal inhibitory concentration: 660 nM
Compound 4: middle estimate off by 44-fold (1.64 log units), on the low side; the measured number lies above the stated range.
By their numbers in this assay, from the lowest: compounds 3 and 2 (each within the scatter of the next); then compound 1; then compound 4.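

In this assay this aromatic carbon, next to the ring nitrogen, proves sensitive: 2-(azetidin-1-yl)pyridin-4-yl in place of phenyl gives a 41-fold higher number from compound 3 to compound 4 (1.62 log units; beyond the scatter) and makes compound 4 the weakest of the series. Within the data shown here, the earlier compounds offered no single step at this position, so this is the first sign of how strongly the assay responds to a change here. No measurement at hand gives a reason for this loss. Still open, on these data alone, is which part of the new group carries the step: a bare pyridin-4-yl, or a dimethylamino group in place of the azetidin-1-yl, would tell the two apart.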